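Amide substituent change on the biaryl carboxamide: compound 4

This account rests on a few compounds, and the source may have more. Where it says the series, first, only, none or still open, it means among the compounds named here.

Measured so far:
- compound 1, `COc1ccc(-c2cccc(C(=O)N(C)C)c2)cc1S(=O)(=O)Nc1cccc(NCC(C)NC(=O)c2cccc(C)c2)c1`: in a functional assay on CHO-RD-HGA16 cells for agonist activity at Orexin/Hypocretin receptor type 1 (Homo sapiens), read by fluorescence and calcium flux, with a stated time of 30 min (on this read-out higher numbers stand for an effect only at larger amounts of compound and lower numbers for an effect already at smaller amounts), compound 1 gives 666 nM.
- compound 2, `COc1ccc(CCC(=O)N(C)C)cc1S(=O)(=O)Nc1cccc(NCCNC(=O)c2cccc(C)c2)c1`: compound 2 gives only the limit > 10000 nM in this assay.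
- compound 3, `COc1ccc(-c2cccc(C(=O)NCCN(C)C)c2)cc1S(=O)(=O)Nc1cccc(NCCNC(=O)c2cccc(C)c2)c1`: compound 3 likewise gives only the limit > 10000 nM in this assay.

Compound 3 therefore stands at the limit of this assay, not at a number; it shares this with one other value in the set, as the limit of > 10000 nM in this assay, at which 2 of the 3 values shown sit, states. Only compound 1 returns a measured value.

The next structure is compound 4, `COc1ccc(-c2cccc(C(=O)N(C)Cc3cccnc3)c2)cc1S(=O)(=O)Nc1cccc(NCCNC(=O)c2cccc(C)c2)c1`. Compared with compound 3, the change is methyl((pyridin-3-yl)methyl)amino in place of (2-(dimethylamino)ethyl)amino on a carbonyl carbon. The amide thus loses its hydrogen-bond donor and gains an aromatic ring. For the measured compounds named here, compound 1, the only compound with a numerical value, carries a tertiary amide at the same position but also differs from compound 4 in the linker, so no single step isolates the amide change.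

A measurable value is expected for compound 4, since compound 1 with its tertiary amide gives 666 nM. Compound 4 is expected to give 3000 nM, with a range from 600 nM to 15000 nM. The expected step is an at least 3.3-fold lower number from compound 3 to compound 4 (0.52 log units; beyond the scatter), beyond the scatter but with a real chance that only a limit is returned again.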

Compound 4, half-maximal effective concentration: 460 nM
For compound 4 the middle estimate is 6.5-fold (0.81 log units) above the measured one, and the stated range ends above it.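

In this assay, the carbonyl carbon bearing the amide substituent proves to be a place where a single change separates a compound at the limit from one with a measured value: methyl((pyridin-3-yl)methyl)amino in place of (2-(dimethylamino)ethyl)amino gives an at least 21-fold lower number from compound 3 to compound 4 (1.33 log units; beyond the scatter). Compound 4 also shows that the chain carried by compound 2, compound 3 and compound 4 is compatible with a measured value, which compound 1 could not show, since it carries a different chain. The true size of the step stays unknown because only a bound can be given when one end of the pair is a limit: the limit of > 10000 nM in this assay, at which 2 of the 4 values shown sit.

The pair changes several features together, namely the amide hydrogen, the aromatic ring and the loss of the dimethylamino group, so it does not show which of them carries the gain. A benzyl(methyl)amino group would test the ring nitrogen, and a (pyridin-3-yl)methylamino group would test the amide hydrogen, while the effect of the methyl group on the chain of compound 1 remains unisolated.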